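A few compounds are considered here, and "the series" means these few. Any claim that something is new, unique, unknown or untested is made for them only; others in the source may bear on it.

Measured so far in an assay for inhibition of Tryptophan 2,3-dioxygenase (Homo sapiens), with stated times of 10 min and 60 min, tested at 10 uM; on this read-out higher numbers stand for a stronger effect at the one concentration tested and lower numbers for a weaker effect:
Compound 1 `FC(F)(F)c1cc(NCC2CNC2)c2cn[nH]c2c1` gives 5%
Compound 2 `Nc1cccc(CNc2cc(C(F)(F)F)cc3[nH]ncc23)c1` gives 68%

Compound 2 holds the higher of the two numbers. Its nearest neighbour is compound 1, and the step of a number 63 percentage points higher from compound 1 to compound 2 (beyond the scatter) came with the change of the whole group on the chain carbon, from azetidin-3-yl to 3-aminophenyl.

Compound 3 `FC(F)(F)c1cc(NCc2cccc(Br)c2)c2cn[nH]c2c1` is not yet measured. Its difference from compound 2 is bromo in place of amino on an aromatic carbon. Among the compounds with values here, the one measured step swapped an entire ring group, while this one touches a single atom on a ring that stays in place, so that step gives no direct guide to the size or direction of the new one. Without a closer precedent, the expectation is an estimated step of a number 13 percentage points lower from compound 2 to compound 3 (beyond the scatter), with a wide range. Compound 3 is therefore expected to give about 55%, estimated between 25% and 85%.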

Compound 3, a percentage reported as inhibition, at one concentration (the size of the read-out at that concentration, not a potency): 67%
The estimate for compound 3 lay 12 percentage points below the measured number; the measured number falls inside the stated range.
By their numbers in this assay, from the lowest: compound 1; then compounds 3 and 2 (each within the scatter of the next).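

In this assay, bromo in place of amino on the aromatic carbon gives a number 1 percentage points lower from compound 2 to compound 3 (within the scatter) and so this place on the ring holds either group with no readable difference, although amino carries a hydrogen-bond donor and acceptor and bromo carries neither. The other new comparison, a number 62 percentage points higher from compound 1 to compound 3 (beyond the scatter), matches the large step seen with 3-aminophenyl, so the higher number over azetidin-3-yl does not depend on having amino on the phenyl ring. No measurement available here explains why amino and bromo read alike.

On these data alone, whether a plain phenyl ring without any group here, or a methoxy group, a nitrile or a carboxylic acid at this place, would read the same remains open. These numbers each come from one concentration, so they show only how strong or weak the effect of each compound is at that concentration.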